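This account rests on a few compounds, and the source may have more. Where it says the series, first, only, none or still open, it means among the compounds named here.

Two compounds in this set share one core and differ only in a single group on a saturated chain carbon bound to an aromatic carbon and a saturated chain carbon. Compound 1 `CCOC(CC(=O)O)c1ccc(OCC2COc3ccc(Cl)cc3O2)cc1` carries an ethoxy group there, and in a functional assay on HEK293 cells for agonist activity at Free fatty acid receptor 1 (Homo sapiens), read by fluorescence and calcium flux, with a stated time of 10 min (a higher number here means a larger maximal response, a lower number a smaller maximal response), compound 1 gives 46%. Compound 2 `Cn1nncc1C(CC(=O)O)c1ccc(OCC2COc3ccc(Cl)cc3O2)cc1` carries a 1-methyl-1H-1,2,3-triazol-5-yl group in the same place, and in this assay compound 2 gives 70%. Within the data shown here, the only measured step, a number 24 percentage points higher from compound 1 to compound 2 (beyond the scatter), shows that the aromatic ring in place of the ethoxy group went with a larger maximal response. Among the measured compounds shown here, compound 2 thus stands highest of the two numbers, with compound 1 as its sole neighbour.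

Compound 3 `O=C(O)CC(c1ccncc1)c1ccc(OCC2COc3ccc(Cl)cc3O2)cc1` is not yet measured. It differs from compound 2 in one place: pyridin-4-yl in place of 1-methyl-1H-1,2,3-triazol-5-yl on a saturated chain carbon bound to an aromatic carbon and a saturated chain carbon. For the measured compounds named here, the one step that bears on this change is a number 24 percentage points higher from compound 1 to compound 2 (beyond the scatter), yet that step swapped a non-aromatic group for an aromatic ring, whereas here one aromatic ring replaces another, so any change is expected to be smaller and may stay within the scatter. For compound 3 the expected step is a number 8 percentage points lower from compound 2 to compound 3 (within the scatter). The estimate for compound 3 in this assay is 62%, with a range from 45% to 80%.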

Compound 3, largest response reached (Emax), in percent of the reference or control that the assay uses: 62%
Compound 3: the middle estimate sits on the measured number at the digits printed; the range from low to high includes it.
By their numbers in this assay, from the lowest: compound 1; then compounds 3 and 2 (each within the scatter of the next).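

The step of a number 8 percentage points lower from compound 2 to compound 3 (within the scatter) in this assay shows that at this position, on a saturated chain carbon bound to an aromatic carbon and a saturated chain carbon, 1-methyl-1H-1,2,3-triazol-5-yl and pyridin-4-yl cannot be told apart, although one is a five-membered aromatic ring with 3 hetero atoms and the other a six-membered aromatic ring with 1 hetero atom. The step of a number 16 percentage points higher from compound 1 to compound 3 (beyond the scatter) adds that the larger maximal response seen against ethoxy is not confined to the triazole, since both aromatic rings shown give it, and no compound here goes against this. No measurement at hand explains why these two rings give such close results or why either differs from ethoxy.

From the compounds shown here alone, whether a plain phenyl ring, with no nitrogen in it, or a saturated ring such as cyclohexyl would stand with the two aromatic rings or with ethoxy stays open. Going by these compounds, it is also open how a longer chain such as propoxy, or an amine, would fare at this same place.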